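The source may hold more compounds than are shown below. What is called first, only, known or untested is meant among the compounds shown, and "the series" means these compounds.

Compound 1 `Cc1ncccc1Oc1ccc(-c2ccn(CC3CC3)c(=O)c2C#N)cc1Cl` gives 230 nM in a functional assay on CHO cells for positive allosteric modulation of metabotropic glutamate receptor 2 (Homo sapiens), read by scintillation counting and GTPgammaS binding, with a stated time of 30 min; a higher number here means that more compound is needed for the effect, a lower number that less compound is needed. Compound 2 `CCCCn1ccc(-c2ccc(Oc3ccc(C)nc3C)c(Cl)c2)c(C#N)c1=O` gives 30 nM in this assay, the lowest of the two numbers and clearly apart from compound 1. Compound 3 `Cc1ccc(Oc2ccc(-c3ccn(CC4CC4)c(=O)c3C#N)cc2Cl)c(C)n1` keeps the core of compound 2 and differs from it only by cyclopropyl in place of propyl on a saturated chain carbon bound to an aromatic nitrogen. Among the measured compounds shown here, no measured pair shows this change on its own, so its size is not known from the data; a modest rise in the number, somewhat beyond the scatter, is expected rather than a large one. The expected step of a 2.0-fold higher number from compound 2 to compound 3 (0.30 log units; within the scatter) leads to an estimated value for compound 3 of 60 nM, with a range from 25 nM to 150 nM.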

Compound 3, half-maximal effective concentration: 64 nM
Compound 3: the middle estimate sits 1.1-fold (0.03 log units) below what was measured, within the range that was stated.
By their numbers in this assay, from the lowest: compound 2; then compound 3; then compound 1.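

Cyclopropyl in place of propyl on a saturated chain carbon bound to an aromatic nitrogen gives a 2.1-fold higher number from compound 2 to compound 3 (0.33 log units; beyond the scatter) in this assay and so changes the number only modestly. With cyclopropyl in place, methyl in place of hydrogen on an aromatic carbon gives a 3.6-fold lower number from compound 1 to compound 3 (0.56 log units; beyond the scatter) as a modest step in the opposite direction. Nothing given here explains either step.

Still open, as far as these compounds go, is how a longer chain such as pentyl, or a chain ending in an amine, would fare at this place. Also open, from the compounds shown here alone, is whether the methyl step keeps its size when butyl replaces cyclopropylmethyl.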